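The compounds below may be only part of what the source reports. "The series", "measured", "known", "first", "only" and "open" are said of these compounds alone.

Measured compounds:
- compound 1, `CC(C)(C)C(=O)NCCCCN1CCN(c2ccccc2)CC1`: 316 nM
- compound 2, `CC(C)(C)C(=O)NCCCCN1CCN(c2ccc(Br)cc2)CC1`: 31.6 nM
- compound 3, `CC(C)(C)C(=O)NCCCN1CCN(c2ccc(Cl)cc2)CC1`: 200 nM

All three were tested in an assay on HEK293 cells for binding affinity to D(4) dopamine receptor (Homo sapiens), read by radioligand binding; a higher number here means a weaker inhibitor, a lower number a stronger inhibitor. Among these three numbers compound 3 stands second highest: compound 1 sits nearby with a number that is within the scatter of it, while compound 2 sits well apart with a clearly lower number. Among the compounds with values here, the only single-point step available is a 10-fold lower number from compound 1 to compound 2 (1.00 log units; beyond the scatter), which concerns a change on the aromatic ring and says nothing about the amide end of the chain.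

Compound 4, `CC(=O)NCCCCN1CCN(c2ccc(Cl)cc2)CC1`, has not been measured. It differs from compound 3 by acetamidomethyl in place of ((tert-butyl)carbonyl)amino on a saturated chain carbon, three bonds along the chain from an amine nitrogen in a ring. Within the data shown here, no measured pair isolates this change; compound 1 and compound 3 differ in two places at once, and their numbers lie within the scatter of each other, so they give no guidance on chain length alone. With nothing that bears directly on the step, the expectation is a number close to that of compound 3, within the scatter, with wide uncertainty. For compound 4 the estimated value in this assay is 250 nM, ranging from 60 nM to 1000 nM, which amounts to an expected step of a 1.3-fold higher number from compound 3 to compound 4 (0.10 log units; within the scatter).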

Compound 4, inhibition constant: 1260 nM
The estimate for compound 4 lay 5.0-fold (0.70 log units) below the measured number; the whole stated range lies below it.
By their numbers in this assay, from the lowest: compound 2; then compounds 3 and 1 (each within the scatter of the next); then compound 4.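

In this assay, the amide end of the chain proves to be a sensitive place: acetamidomethyl in place of ((tert-butyl)carbonyl)amino gives a 6.3-fold higher number from compound 3 to compound 4 (0.80 log units; beyond the scatter). Within the data shown here, until now, the only readable step lay on the aromatic ring, so this is the first sign that the core's other end also matters for this receptor. The two groups have the same counts of hydrogen-bond donors and acceptors and no net charge, differing in size at 5 against 7 heavy atoms, and no measurement here gives a reason for the step.

This single swap alters both the amide end and the link to the chain, and the compounds shown do not pull those two parts apart. On these data alone, how a longer chain, or a benzamide at the amide end, would behave also remains open.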